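The source may report more compounds than this note shows. Statements on the series, on what has been measured and on what is new or still open speak of the compounds shown alone.

Measured compounds, cytotoxicity in a functional assay on HCC 2998 cells (Homo sapiens) for cytotoxicity, read by sulforhodamine B assay, with a stated time of 48 h; a lower number here means that less compound is tolerated, a higher number that more compound is tolerated:

compound 1, `ClCc1ccccc1Cn1cnc2c(Cl)nc(Cl)nc21`: 6160 nM
compound 2, `ClCc1ccccc1Cn1cnc2c(Cl)ncnc21`: 7410 nM
compound 3, `ClCc1ccc(Cn2cnc3nc(Cl)nc(Cl)c32)cc1`: 7070 nM

Of the three numbers, that of compound 2 is the highest, but neither of the other two is separated from it by more than the scatter: compound 3 sits nearest and compound 1 furthest, both within the usual spread of repeats. For the measured compounds named here, the only single-point step among the measured compounds is a 1.2-fold higher number from compound 1 to compound 2 (0.08 log units; within the scatter), and it stays within the scatter.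

Compound 4, `Nc1nc(Cl)c2ncn(Cc3ccccc3CCl)c2n1`, is not yet measured. Relative to compound 2 the change is amino in place of hydrogen on an aromatic carbon. Going by the values given here, no measured pair shows an amino group entering anywhere on the core, so no step speaks directly to this change; the one step that exists, exchanging chloro for hydrogen on the core, produced nothing beyond the scatter. The expectation for compound 4 is therefore a number close to that of compound 2, with the estimated step of a 1.1-fold higher number from compound 2 to compound 4 (0.03 log units; within the scatter). Compound 4 is estimated at 8000 nM, within a range of 3000 nM to 20000 nM.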

Compound 4, concentration lethal to 50% of the cells: 26300 nM
Estimate against measurement, compound 4: 3.3-fold (0.52 log units) below; the whole stated range lies below it.
By their numbers in this assay, from the lowest: compounds 1, 3 and 2 (each within the scatter of the next); then compound 4.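

In this assay, the aromatic carbon between two ring nitrogen atoms now proves able to shift the number: amino in place of hydrogen gives (a 3.5-fold higher number from compound 2 to compound 4 (0.55 log units; beyond the scatter)), whereas hydrogen in place of chloro at the same carbon gave only (a 1.2-fold higher number from compound 1 to compound 2 (0.08 log units; within the scatter)). Amino in place of chloro points the same way (a 4.3-fold higher number from compound 1 to compound 4 (0.63 log units; beyond the scatter)), so among the three groups seen at this carbon, amino alone separates from the others, with more compound tolerated. Nothing at hand accounts for this shift.

On these data alone, whether the shift is particular to amino stays open; methylamino or hydroxyl at this carbon would help to settle that. Also open, as far as these compounds go, is whether amino gives a similar step with the chloromethyl group placed as in compound 3.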